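The compounds below may be only part of what the source reports. "The series", "measured", "known", "first", "only" and "open" are said of these compounds alone.

Measured compounds:
compound 1, `Cc1nc(SCC(=O)Nc2nc(-c3ccc(Cl)cc3)cs2)n(Nc2ccccc2)c1C`: 2900 nM
compound 2, `Cc1ccc(Nn2c(SCC(=O)Nc3nc(-c4ccccc4)cs3)nc(C)c2C)cc1`: 3030 nM

Both compounds were tested in a functional assay on A549 cells (Homo sapiens) for antiproliferative activity, read by sulforhodamine B assay, with a stated time of 48 h; on this read-out lower numbers stand for stronger inhibition of growth and higher numbers for weaker inhibition of growth. Compound 1 gives 2900 nM in this assay, and compound 2 gives 3030 nM; the two numbers lie within the scatter of each other, so neither can be called the stronger. Compound 1 has the lowest number of the two, but only nominally. For the measured compounds named here, no single-point step between compound 1 and compound 2 is available, since the two differ in more than one place.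

Compound 3, `COc1ccc(Nn2c(SCC(=O)Nc3nc(-c4ccc(Cl)cc4)cs3)nc(C)c2C)cc1`, has not yet been measured in this assay. It differs from compound 1 by methoxy in place of hydrogen on an aromatic carbon, that is, a methoxy in place of hydrogen on an aromatic carbon, while the chloro-bearing ring of compound 1 is kept. Going by the values given here, no measured pair shows the effect of this change, so the size of the step from compound 1 to compound 3 in this assay cannot be read from the data; with compound 1 at 2900 nM and compound 2 at 3030 nM lying together, a step of no more than the scatter, in either direction, is expected. On that basis compound 3 is estimated at 2500 nM in this assay, within 1000 nM to 6500 nM, which corresponds to an expected step of a 1.2-fold lower number from compound 1 to compound 3 (0.06 log units; within the scatter).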

Compound 3, concentration for 50% growth inhibition: 3320 nM
Compound 3: middle estimate off by 1.3-fold (0.12 log units), on the low side; measured number inside the range.
By their numbers in this assay, from the lowest: compounds 1, 2 and 3 (each within the scatter of the next).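

The change from anilino to (4-methoxyphenyl)amino, a methoxy in place of hydrogen on an aromatic carbon para to a large group, can now be read directly in this assay: the step is a 1.1-fold higher number from compound 1 to compound 3 (0.06 log units; within the scatter). The earlier compounds shown here could not show this, as they differ in more than one place, whereas this single pair shows that, with the chloro-bearing ring kept, methoxy at this carbon leaves the number within the scatter of that with hydrogen. No accompanying measurement bears on why the two numbers lie together.

This single pair does not show whether a carboxylic acid, an amine or a longer chain such as butoxy at the same carbon would also stay within the scatter, or would instead move the number beyond it. It also leaves open whether methoxy at this carbon would give a similar step without the chloro-bearing ring, or whether a methoxy on another carbon of the same ring would do so.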